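From furan-3-yl to a non-aromatic ring on growth inhibition

The compounds below may be only part of what the source reports. "The series", "measured", "known", "first", "only" and "open" are said of these compounds alone.

Three related compounds have been tested so far in a functional assay on A549 cells (Homo sapiens) for inhibition, read by sulforhodamine B assay (on this read-out lower numbers stand for stronger inhibition of growth and higher numbers for weaker inhibition of growth), on these cells. Compound 1 (`CC1(C)CCC[C@]2(C)[C@@H](/C=C/C3=CCOC3=O)C(C=O)=CC(=O)[C@@H]12`) gives 18500 nM in this test, compound 2 (`CC1(C)CCC[C@]2(C)[C@@H](/C=C/C3=CC(=O)OC3)C(CO)=C(O)C(=O)[C@@H]12`) gives 26000 nM in the same test, and compound 3 (`CC1=CC(=O)[C@H]2C(C)(C)CCC[C@]2(C)[C@H]1/C=C/c1ccoc1`) gives 7400 nM as the lowest number of the three, clearly apart from the other two.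

Compound 3 carries furan-3-yl on a double-bonded chain carbon bound to a double-bonded chain carbon. Compound 4 (`CC1=CC(=O)[C@H]2C(C)(C)CCC[C@]2(C)[C@H]1/C=C/C1=CCOC1=O`) keeps the rest of compound 3, and the change (a group of 6 heavy atoms (4 carbon, 2 oxygen; one five-membered non-aromatic ring with 1 hetero atom) in place of a group of 5 heavy atoms (4 carbon, 1 oxygen; one five-membered aromatic ring with 1 hetero atom), on a double-bonded chain carbon bound to a double-bonded chain carbon) puts a non-aromatic ring where the aromatic one stood.

Going by the values given here, no pair of measured compounds differs by this change alone, so any forecast is indirect. Compound 1 also has a five-membered non-aromatic ring with 1 hetero atom at that place, although its core differs too, and compound 1 reads 18500 nM as a higher number than that of compound 3. A moderate rise in this assay therefore seems likely, meaning weaker inhibition of growth, and the estimated step is a 1.6-fold higher number from compound 3 to compound 4 (0.21 log units; within the scatter) on this evidence. For compound 4 the expected value is 12000 nM within an estimated range of 5000 nM to 28000 nM in this test.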

Compound 4, concentration for 50% growth inhibition: 21700 nM
Estimate against measurement, compound 4: 1.8-fold (0.26 log units) below; measured number inside the range.
By their numbers in this assay, from the lowest: compound 3; then compounds 1, 4 and 2 (each within the scatter of the next).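

In this assay, putting the non-aromatic ring in place of furan-3-yl, on a double-bonded chain carbon bound to a double-bonded chain carbon, gives a 2.9-fold higher number from compound 3 to compound 4 (0.47 log units; beyond the scatter). Going by these compounds alone, this is the first reading of that change alone with the rest of the molecule held fixed, so it shows that this position matters for growth inhibition on these cells and that the aromatic furan-3-yl goes with the stronger inhibition of this pair. With the non-aromatic ring kept in place, the second step, methyl in place of formyl on a double-bonded ring carbon, gives a 1.2-fold higher number from compound 1 to compound 4 (0.07 log units; within the scatter), so this pair shows that the swap at the ring carbon does not move the number beyond the usual scatter, unlike the swap on the chain.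

Nothing available here says what lies behind the rise on leaving furan-3-yl. As far as these compounds go, how a phenyl ring or a carboxylic acid would read on that chain carbon stays open, as does how an amine would read on the double-bonded ring carbon that holds the methyl or formyl.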